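A few compounds are considered here, and "the series" means these few. Any claim that something is new, unique, unknown or untested is made for them only; others in the source may bear on it.

Measured compounds:
- compound 1, `CN1C[C@H]2C=C(c3cccnc3)C[C@H](C2)C1`: > 10000 nM
- compound 2, `C1=C(c2cccnc2)C[C@@H]2CNC[C@H]1C2`: 2.3 nM

In an in vitro functional assay on SH-EP1 cells for agonist activity at Neuronal acetylcholine receptor; alpha4/beta2 (Homo sapiens), read by FLIPR and calcium flux (on this read-out higher numbers stand for an effect only at larger amounts of compound and lower numbers for an effect already at smaller amounts), compound 1 reports only a limit, > 10000 nM, at the edge of the assay; this is the limit of > 10000 nM in this assay, at which 1 of the 2 values shown sits. Among the measured compounds shown here, compound 2, `C1=C(c2cccnc2)C[C@@H]2CNC[C@H]1C2`, gives 2.3 nM in this assay and so stands as the only numerical value.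

Compound 3, `CN1C[C@@H]2C=C(c3cccnc3)C[C@@H](C2)C1`, differs from compound 2 by methyl in place of hydrogen on an amine nitrogen in a ring. For the measured compounds named here, no measured step of this kind exists, so the size and direction of its effect are open. Taking compound 2 at 2.3 nM as the starting point, compound 3 is expected to be weaker by a 22-fold higher number from compound 2 to compound 3 (1.34 log units; beyond the scatter), with wide uncertainty. The estimate for compound 3 in this assay is 50 nM, within 5 nM to 1000 nM.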

Compound 3, half-maximal effective concentration: 6660 nM
Estimate against measurement, compound 3: 130-fold (2.12 log units) below, and the stated range ends below it.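

In this assay, among the compounds shown here, the first measured change at this position is large: a 2900-fold higher number from compound 2 to compound 3 (3.46 log units; beyond the scatter), so in this configuration methyl in place of hydrogen on the amine nitrogen moves the number well beyond the scatter. Compound 1 gives only a limit, > 10000 nM. The reading an at least 1.5-fold lower number from compound 1 to compound 3 (0.17 log units; that floor lies within the scatter) therefore establishes no preference between the two drawn configurations of the methyl compound, and this comparison isolates configuration alone on this ground: the fact that compounds 1 and 3 differ only in the configuration as drawn

On these data alone, how the mirror image of compound 2 behaves stays open, so the role of configuration with hydrogen on the nitrogen cannot be judged from these compounds. As far as these compounds go, whether an ethyl group, a longer chain or an acetyl group on the same nitrogen would track with methyl also stays open.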